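The source may hold more compounds than are shown below. What is called first, only, known or untested is meant among the compounds shown, and "the series" means these compounds.

Of the compounds shown here, two have so far been tested in a functional assay on the whole organism (strain CD1) for inhibition, with Mus musculus as the target, with stated times of 15 min and 20 min, at a dose of 10 mg/kg by the subcutaneous route; a lower number here means less inhibition, a higher number more inhibition at the dose given (going by the name of the read-out). Compound 1 `N#C/C(=C\c1ccc[nH]1)C(=O)OC1CCCCC1` gives 10% in this assay. Compound 2 `CCOC(=O)/C(C#N)=C/c1cc2ccccc2[nH]1` gives 88.4% in this assay, the highest of the two numbers, and its gap to compound 1 lies beyond the scatter, so the inhibition of compound 2 in this assay is the higher of the pair.

Compound 3 `CCNC(=O)/C(C#N)=C/c1cc2ccccc2[nH]1` has not yet been measured in this assay. It differs from compound 2 in one place: ethylamino in place of ethoxy on a carbonyl carbon. For the measured compounds named here, no two measured compounds differ in just this way, so there is no measured step of this kind to lean on, and the estimate below rests on the number of compound 2 alone.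

Compound 3 is expected to stay fairly close to that number, with an expected step of a number 18.4 percentage points lower from compound 2 to compound 3 (beyond the scatter), a modest fall. The estimate for compound 3 in this assay is 70%, with a range from 35% to 92%.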

Compound 3, a percentage reported as inhibition, in the whole organism at one dose (the size of the read-out at that dose, not a potency): 45%
Beside the measured number, compound 3's estimate is 25 percentage points above it; the measured number falls inside the stated range.
By their numbers in this assay, from the lowest: compound 1; then compound 3; then compound 2.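

In this assay, putting ethylamino in place of ethoxy on a carbonyl carbon, with the rest of the structure unchanged, gives a number 43.4 percentage points lower from compound 2 to compound 3 (beyond the scatter) and shows that the read-out is sensitive to this change at this position. The two groups have the same number of heavy atoms and neither carries a ring or a net charge, but ethylamino swaps the oxygen for nitrogen and brings a hydrogen-bond donor. Nothing available here shows what lies behind the fall.

The compounds shown leave open whether the amide hydrogen matters, which dimethylamino on the same carbonyl carbon could help to separate from the swap of oxygen for nitrogen. As far as these compounds go, how a longer chain on that nitrogen or a carboxylic acid in place of the ester would read also stays open.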